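Benzyl in Place of Phenoxy on a Serine Phosphate Ester Series

The compounds below may be only part of what the source reports. "The series", "measured", "known", "first", "only" and "open" are said of these compounds alone.

Compound 1: `N[C@@H](COP(=O)(O)OCCCOC(=O)CCc1ccccc1OCCCCCCOc1ccccc1)C(=O)O`, 20.7%
Compound 2: `N[C@@H](COP(=O)(O)OCCCOC(=O)CCc1ccccc1OCc1cccc(Oc2ccccc2)c1)C(=O)O`, 19.4%

Of the compounds shown here, two of this set have been measured in an assay on cells for agonist activity at probable G-protein coupled receptor 34 (Mus musculus), with a stated time of 1 h; a lower number here means a smaller maximal response, a higher number a larger maximal response. Compound 1 gives 20.7%, and compound 2 gives 19.4%. The two numbers lie within the usual scatter of each other, so no order between compound 1 and compound 2 can be read from them; both sit in the same low band of maximal response. Compound 3, `N[C@@H](COP(=O)(O)OCCCOC(=O)CCc1ccccc1OCc1cccc(Cc2ccccc2)c1)C(=O)O`, has not yet been measured. It differs from compound 2 in a single place: benzyl in place of phenoxy on an aromatic carbon. Among the compounds with values here, no step between measured compounds is available that would show what such an exchange does here, and the pair at hand offers only two close values as a baseline. The expectation for compound 3 is therefore a step that stays within the scatter, without a clear direction, namely a number 0.6 percentage points higher from compound 2 to compound 3 (within the scatter). On that basis compound 3 is estimated to give 20% in this assay, with a range from 9% to 32%.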

Compound 3, largest response reached (Emax), in percent of the reference or control that the assay uses: 14.5%
Beside the measured number, compound 3's estimate is 5.5 percentage points above it; the range from low to high includes it.
By their numbers in this assay, from the lowest: compounds 3, 2 and 1 (each within the scatter of the next).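

Within the data shown here, the exchange of phenoxy for benzyl on an aromatic carbon, meta to a large group, is the first single-place change that can be read in this assay: it gives a number 4.9 percentage points lower from compound 2 to compound 3 (within the scatter). This replaces the oxygen of phenoxy with carbon, taking the count of hydrogen-bond acceptors in the group from 1 to 0 while keeping the 7 heavy atoms and the six-membered aromatic ring, and the step stays within the scatter, so neither a loss nor a gain of maximal response can be claimed for this change. Nothing available bears on why the exchange gives this result.

With only this one step at this place, the compounds shown do not tell whether any group there can move the maximal response beyond the scatter, for instance an amine or a carboxylic acid on the ring of the benzyl group, or a longer chain in place of its single carbon link. From the compounds shown here alone, whether the same exchange would give a similar step on another core also remains open.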